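A few compounds are considered here, and "the series" means these few. Any claim that something is new, unique, unknown or untested is made for them only; others in the source may bear on it.

The series shares the core seen in compound 1 `c1ccc(-c2cn3ccnc3c(-c3ccc4ncn(C5CCCCC5)c4c3)n2)cc1` and varies the aryl group attached to it. In a functional assay on BT-549 cells (Homo sapiens) for inhibition, read by sulforhodamine B assay, with a stated time of 48 h, tested at 10 uM (a lower number here means less inhibition, a higher number more inhibition at the concentration tested (going by the name of the read-out)), compound 1 gives 57.1%. Compound 2 `CC(=O)c1ccc(-c2cn3ccnc3c(-c3ccc4ncn(C5CCCCC5)c4c3)n2)cc1` carries an acetyl group and in this assay compound 2 gives 4.68%, while compound 3 `Clc1ccc(-c2cn3ccnc3c(-c3ccc4ncn(C5CCCCC5)c4c3)n2)cc1` carries a chloro group and in this assay compound 3 gives 23.8%. Compound 3 thus stands second of the three, with compound 2 some way below it and compound 1 further above it. The unmeasured compound 4 `c1csc(-c2cn3ccnc3c(-c3ccc4ncn(C5CCCCC5)c4c3)n2)c1` differs from compound 3 as follows: thiophen-2-yl in place of 4-chlorophenyl on an aromatic carbon. Going by the values given here, no measured step introduces a thiophen-2-yl group, so the relevant comparisons are indirect: a number 33.3 percentage points lower from compound 1 to compound 3 (beyond the scatter), a number 52.4 percentage points lower from compound 1 to compound 2 (beyond the scatter) and a number 19.1 percentage points higher from compound 2 to compound 3 (beyond the scatter). Removing a substituent from the aryl ring has, in this set, returned inhibition toward the level of compound 1, and the thiophen-2-yl group carries no such substituent. The account therefore expects a modest rise, a number 16.2 percentage points higher from compound 3 to compound 4 (beyond the scatter), for compound 4 in this assay, with an estimated value of 40% in a range from 15% to 65%.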

Compound 4, a percentage reported as inhibition, at one concentration (the size of the read-out at that concentration, not a potency): 12.2%
For compound 4 the middle estimate is 27.8 percentage points above the measured one; the measured number lies below the stated range.
By their numbers in this assay, from the lowest: compounds 2 and 4 (each within the scatter of the next); then compound 3; then compound 1.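

In this assay, exchanging the phenyl ring for another unsubstituted aromatic ring also lowers inhibition, with thiophen-2-yl giving (a number 44.9 percentage points lower from compound 1 to compound 4 (beyond the scatter)), so the absence of a substituent does not by itself preserve the level of compound 1. The change from 4-chlorophenyl gives (a number 11.6 percentage points lower from compound 3 to compound 4 (beyond the scatter)), while the comparison with the acetyl-bearing ring gives (a number 7.5 percentage points higher from compound 2 to compound 4 (within the scatter)), leaving compound 1 with the highest number of the four and showing that this position responds to replacement of the ring itself, not only to substitution on it. Nothing available explains this response. Going by these compounds, it remains open whether an amine or a methyl group on the phenyl ring would retain inhibition. Whether furan-2-yl or a pyridine ring would behave like thiophen-2-yl or like phenyl also remains unresolved.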